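Replacing fluoro with pyridin-3-yl on the aromatic carbon

The source may hold more compounds than are shown below. What is called first, only, known or untested is meant among the compounds shown, and "the series" means these compounds.

Measured in an assay on CHO cells for antagonist activity at transient receptor potential cation channel subfamily V member 1 (Homo sapiens), read by FLIPR; on this read-out lower numbers stand for stronger inhibition and higher numbers for weaker inhibition:
compound 1 `CC(C(=O)NCc1ccc(C(F)(F)F)cc1N1CCC(C)(C)CC1)c1ccc(NS(C)(=O)=O)c(F)c1`: 1.3 nM
compound 2 `CC(C(=O)NCc1ccc(C(F)(F)F)cc1OC1CCCCC1)c1ccc(NS(C)(=O)=O)c(F)c1`: 0.7 nM
compound 3 `CC(C(=O)NCc1ccc(C(F)(F)F)cc1F)c1ccc(NS(C)(=O)=O)c(F)c1`: 68.7 nM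

Compound 3 holds the highest number of the three, beyond the scatter against both others: a 53-fold higher number from compound 1 to compound 3 (1.72 log units; beyond the scatter) and a 98-fold higher number from compound 2 to compound 3 (1.99 log units; beyond the scatter). Compound 1 and compound 2 lie within the scatter of each other, a 1.9-fold lower number from compound 1 to compound 2 (0.27 log units; within the scatter).

The next compound, compound 4 `CC(C(=O)NCc1ccc(C(F)(F)F)cc1-c1cccnc1)c1ccc(NS(C)(=O)=O)c(F)c1`, differs from compound 3 in one place: pyridin-3-yl in place of fluoro on an aromatic carbon. The two measured steps that bear on this are the ones in which a group on that aromatic carbon was exchanged for fluoro, from compound 1 and from compound 2 to compound 3. Both were large and in the same direction, with 4,4-dimethylpiperidin-1-yl and cyclohexyloxy giving far lower numbers than fluoro. Compound 4 again carries a ring on that carbon, so a large step to a lower number in this assay is expected. The step expected is a 23-fold lower number from compound 3 to compound 4 (1.36 log units; beyond the scatter). Compound 4 is estimated at 3 nM, with a range from 0.8 nM to 15 nM.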

Compound 4, inhibition constant: 59.4 nM
The estimate for compound 4 lay 20-fold (1.30 log units) below the measured number, outside the stated range (above it).
By their numbers in this assay, from the lowest: compounds 2 and 1 (each within the scatter of the next); then compounds 4 and 3 (each within the scatter of the next).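

In this assay a ring on this aromatic carbon does not by itself bring the low numbers of compound 1 and compound 2: a 1.2-fold lower number from compound 3 to compound 4 (0.06 log units; within the scatter) leaves pyridin-3-yl and fluoro not told apart. With an 85-fold higher number from compound 2 to compound 4 (1.93 log units; beyond the scatter) and a 46-fold higher number from compound 1 to compound 4 (1.66 log units; beyond the scatter) pyridin-3-yl does not stand in for cyclohexyloxy or 4,4-dimethylpiperidin-1-yl, so among these compounds the low numbers at this place go with those two groups and not with a six-membered ring as such. Nothing available accounts for this difference.

The compounds shown leave open whether the link through oxygen or nitrogen matters, or the lack of aromaticity in the ring. A phenyl group, a directly attached cyclohexyl group or an unsubstituted piperidin-1-yl group at this place would separate these readings.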